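This account rests on a few compounds, and the source may have more. Where it says the series, first, only, none or still open, it means among the compounds named here.

In an assay on cells for inhibition of Palmitoleoyl-protein carboxylesterase NOTUM variant C330S (Homo sapiens), read by fluorescence, with a stated time of 40 min (a lower number here means a stronger inhibitor, a higher number a weaker inhibitor), compound 1 `Cc1cc(C(=O)O)c(C)n1-c1ccc(Cl)cc1Cl` gives 430 nM. Compound 2 `CNC(=O)C1CCN(c2ccc(Cl)c(C(F)(F)F)c2)C1` gives 1300 nM in this assay, the higher of the two numbers, and the gap to compound 1 lies beyond the usual scatter. Compound 3 `O=C(C1CCN(c2ccc(Cl)c(C(F)(F)F)c2)C1)N1CC2COCC2C1` differs from compound 2 in one place: a group of 8 heavy atoms (6 carbon, 1 nitrogen, 1 oxygen; 2 five-membered non-aromatic rings with 1 hetero atom each) in place of a group of 2 heavy atoms (1 carbon, 1 nitrogen; no ring), on a carbonyl carbon. Among the compounds with values here, no measured pair shows what such a change does, so the direction is open. A step from compound 2 to compound 3 of a 1.4-fold lower number from compound 2 to compound 3 (0.16 log units; within the scatter) is expected, roughly no change beyond the scatter. In this assay compound 3 is estimated at 900 nM, within 250 nM to 3500 nM.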

Compound 3, half-maximal inhibitory concentration: 3100 nM
Beside the measured number, compound 3's estimate is 3.4-fold (0.54 log units) below it, and the stated range covers the measured number.
By their numbers in this assay, from the lowest: compound 1; then compound 2; then compound 3.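

On the carbonyl carbon, swapping methylamino for the larger group of two five-membered rings gives a 2.4-fold higher number from compound 2 to compound 3 (0.38 log units; beyond the scatter) in this assay, a modest loss rather than a collapse. This position therefore tolerates the bulkier group, though not for free. Size, ring count and the hydrogen-bond donor all change in this single step, and no measurement on hand explains the shift.

Still open, on these data alone, is whether dimethylamino, which also has no amide hydrogen but adds no rings, would land nearer compound 2 or compound 3. A single pair cannot separate these changes.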